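Ethylamino for methoxy on a shared core

A few compounds are considered here, and "the series" means these few. Any claim that something is new, unique, unknown or untested is made for them only; others in the source may bear on it.

Of the compounds shown here, two of a common core have been measured in a functional assay on T47D cells (Homo sapiens) for activation; on this read-out higher numbers stand for an effect only at larger amounts of compound and lower numbers for an effect already at smaller amounts. Compound 1 `CCNc1ccc2c(c1)OC(N)=C(C#N)C2c1cccc([N+](=O)[O-])c1` carries an ethylamino group on the core and a nitro group on the pendant phenyl ring; in this assay compound 1 gives 110000000 nM. Compound 2 `COc1cccc(C2C(C#N)=C(N)Oc3cc(OC)ccc32)c1` carries a methoxy group on the core and a methoxy group on the pendant phenyl ring; in this assay compound 2 gives 52000000 nM, the lower of the two numbers, and the gap to compound 1 lies beyond the usual scatter. Compound 3 `CCNc1ccc2c(c1)OC(N)=C(C#N)C2c1cccc(OC)c1` is compound 2 with one change: ethylamino in place of methoxy on an aromatic carbon. Compound 1 also carries the ethylamino group but differs from compound 3 on the pendant phenyl ring as well, so the two known values alone do not isolate the effect of this change. The step from compound 2 to compound 3 in this assay is expected to be small, a 1.3-fold higher number from compound 2 to compound 3 (0.13 log units; within the scatter), possibly not beyond the scatter. Compound 3 is estimated at 70000000 nM, within a range from 25000000 nM to 200000000 nM.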

Compound 3, half-maximal effective concentration: 110000000 nM
The estimate for compound 3 lay 1.6-fold (0.20 log units) below the measured number, and the stated range covers the measured number.
By their numbers in this assay, from the lowest: compound 2; then compounds 1 and 3 (each within the scatter of the next).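

In this assay, ethylamino in place of methoxy on the core can now be read on its own, as compound 2 and compound 3 differ only there: the change gives a 2.1-fold higher number from compound 2 to compound 3 (0.33 log units; beyond the scatter) as a modest step beyond the scatter. The earlier pair could not show this, since compound 1 and compound 2 also carry different groups on the pendant phenyl ring. That ring can now be read separately as well: with ethylamino on the core, methoxy in place of nitro gives no change at the digits printed from compound 1 to compound 3 (within the scatter) and so leaves the read-out unmoved in this pair.

Still open, as far as these compounds go, is whether the step on the core follows from the nitrogen or from the chain, which ethoxy in this place would help to separate from ethylamino, and whether an unsubstituted amine, methylamino or a longer chain such as propylamino would give a lower or higher number. Open too, from the compounds shown here alone, is whether a group such as chlorine or a carboxylic acid on the pendant phenyl ring would leave the read-out as unmoved as nitro and methoxy do.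

Nothing available here accounts for the step on the core.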